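Sulfur to oxygen in the benzyl linker of compound 2

The source may report more compounds than this note shows. Statements on the series, on what has been measured and on what is new or still open speak of the compounds shown alone.

Among the compounds with values here, compound 2 `Cc1cc(N2CCN(C)CC2)nc2ccc(NC(=O)CSCc3ccc(Cl)cc3)cc12` gives the highest of the two numbers so far in an assay on isolated protein for inhibition of melanin-concentrating hormone receptor 1 (Homo sapiens), tested at 1 uM (on this read-out lower numbers stand for less inhibition and higher numbers for more inhibition at the one concentration tested (going by the name of the read-out)), at 38%; compound 1 `COc1cccc(OCC(=O)Nc2ccc3nc(N4CCN(C)CC4)cc(C)c3c2)c1` sits at 9%, and the step of a number 29 percentage points higher from compound 1 to compound 2 (beyond the scatter) is beyond the scatter. Compound 3 `Cc1cc(N2CCN(C)CC2)nc2ccc(NC(=O)COCc3ccc(Cl)cc3)cc12` has not been measured. It differs from compound 2 by (4-chlorobenzyl)oxy in place of (4-chlorobenzyl)sulfanyl on a saturated chain carbon bound to a carbonyl carbon. Within the data shown here, no measured step exchanges only the sulfanyl for an oxy link; the one measured step replaced both the aryl part and the linking atom at once, so it bears on the present change only loosely and its direction cannot be carried over. The expected step is therefore small, a number 8 percentage points lower from compound 2 to compound 3 (within the scatter), not beyond the scatter in this assay and leaning slightly down. Compound 3 is estimated at 30%, within 8% to 55%.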

Compound 3, a percentage reported as inhibition, at one concentration (the size of the read-out at that concentration, not a potency): 19%
Compound 3: middle estimate off by 11 percentage points, on the high side; low and high end bracket the measured number.
By their numbers in this assay, from the lowest: compounds 1 and 3 (each within the scatter of the next); then compound 2.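

In this assay, the sulfanyl-to-oxy exchange on the saturated chain carbon bound to a carbonyl carbon, with 4-chlorobenzyl held constant, gives a number 19 percentage points lower from compound 2 to compound 3 (beyond the scatter) and so isolates the linking atom as a change that matters at this position. With the oxy link held constant, 4-chlorobenzyl in place of 3-methoxyphenyl gives a number 10 percentage points higher from compound 1 to compound 3 (within the scatter), so the aryl change alone stays inside the scatter, and the larger of the two separated changes is the one in the linking atom. Nothing available explains the difference between the sulfur and oxygen links.

On these data alone, whether a sulfanyl link would raise the number with 3-methoxyphenyl as well remains open. Also open, as far as these compounds go, is how an amine link, a sulfonyl link or a longer chain at this position would compare with the sulfanyl link of compound 2.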